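This account rests on a few compounds, and the source may have more. Where it says the series, first, only, none or still open, it means among the compounds named here.

Of the compounds shown here, three have been tested in an ADME assay on U-937 cells (Homo sapiens) for cytotoxicity, read by MTT assay, with a stated time of 24 h; on this read-out lower numbers stand for higher toxicity in this test and higher numbers for lower toxicity in this test. Compound 1 `Clc1ccc(OC(CCn2ccnc2)c2ccccc2)cc1` gives 200000 nM in this assay. Compound 2 `Clc1ccc(OC(CCn2ccnc2)c2ccccc2)c(Cl)c1` differs from it by chloro in place of hydrogen on an aromatic carbon, and in this assay compound 2 gives 166000 nM, so that a 1.2-fold lower number from compound 1 to compound 2 (0.08 log units; within the scatter). Compound 3 `Clc1ccc(C(CCn2ccnc2)Oc2ccccc2)cc1` is built from the same atoms as compound 1, joined differently; the difference between the two cores is not broken down here. In this assay compound 3 gives 248000 nM, a number within the scatter of both compound 1 and compound 2.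

Compound 4 `Clc1ccc(C(CCn2ccnc2)Oc2ccccc2Cl)cc1` has not yet been measured. It differs from compound 3 by chloro in place of hydrogen on an aromatic carbon. For the measured compounds named here, this is the same kind of change as the one from compound 1 to compound 2, not the same: in both cases the new chloro sits ortho to a large group, but in compound 2 it also stands meta to a chloro group, whereas in compound 4 no such neighbour is present. Because a 1.2-fold lower number from compound 1 to compound 2 (0.08 log units; within the scatter), a step of similar size is expected here, namely a 1.2-fold lower number from compound 3 to compound 4 (0.07 log units; within the scatter). For compound 4 the estimated value in this assay is therefore 210000 nM, with a likely range from 120000 nM to 350000 nM.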

Compound 4, half-maximal cytotoxic concentration: 209000 nM
Estimate against measurement, compound 4: 1.0-fold (0.00 log units) above; the range from low to high includes it.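

In this assay, chloro in place of hydrogen on an aromatic carbon gives a 1.2-fold lower number from compound 3 to compound 4 (0.07 log units; within the scatter). Set beside the earlier step, the same change reads alike on the two cores: the same change on two cores in this assay, a 1.2-fold lower number (0.08 log units; within the scatter) from compound 1 to compound 2 and a 1.2-fold lower number (0.07 log units; within the scatter) from compound 3 to compound 4, 1.0-fold (0.01 log units) apart, within the scatter of two such steps. This shows that, on these two cores, the change leaves the number within what repeated measurements would give anyway, so the agreement is between two steps too small to read as real effects; it does not show that chloro has any effect of its own, nor that the result would hold on a third core or at another place on the ring.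

The compounds shown leave open whether a different group at this place, such as an amine, a carboxylic acid or a methoxy group, would give a step beyond the scatter. They also leave open what a longer chain in the shared core would do to the number in this assay.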